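The compounds below may be only part of what the source reports. "The series", "measured", "known", "first", "only" and "open" are said of these compounds alone.

Measured in a functional assay on HeLa cells (Homo sapiens) for cytotoxicity, read by MTT assay, with a stated time of 72 h; a lower number here means a stronger inhibitor, a higher number a weaker inhibitor:
- compound 1 `CC(C)(C)C1=CC(=O)C=C(NCCC(=O)O)C1=O`: 47100 nM
- compound 2 `CC(C)(C)C1=CC(=O)C=C(NCC(=O)O)C1=O`: 132000 nM
- compound 3 `CC1=CCC[C@H]2[C@](C)(CC3=CC(=O)C=C(N[C@@H](CC(C)C)C(=O)O)C3=O)[C@@H](C)CC[C@]12C`: 7720 nM

Compound 3 has the lowest number of these three, so it sets the mark for the next compound. Compound 4 `CC1=CCC[C@H]2[C@](C)(CC3=CC(=O)C=C(NCCC(=O)O)C3=O)[C@@H](C)CC[C@]12C` keeps the core of compound 3 and changes only the acid-bearing group: 2-carboxyethyl in place of 1-carboxy-3-methylbutyl on an amine nitrogen. Among the compounds with values here, the 2-carboxyethyl group that enters is the one compound 1 already carries, on a different core.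

No measurement shows this exact swap on the core of compound 3. Within the data shown here, only one measured step comes close, a 2.8-fold higher number from compound 1 to compound 2 (0.45 log units; beyond the scatter). It is modest, and it shows that changing the acid-bearing chain on this nitrogen can shift the number beyond the scatter. A modest rise in this assay therefore seems likely, meaning a somewhat weaker inhibitor, though the direction is uncertain. The expected change is a 1.8-fold higher number from compound 3 to compound 4 (0.26 log units; within the scatter). Compound 4 is estimated at 14000 nM, with an expected range of 5000 nM to 40000 nM.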

Compound 4, half-maximal inhibitory concentration: 8870 nM
Estimate against measurement, compound 4: 1.6-fold (0.20 log units) above, within the range that was stated.
By their numbers in this assay, from the lowest: compounds 3 and 4 (each within the scatter of the next); then compound 1; then compound 2.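

In this assay, the step from 1-carboxy-3-methylbutyl to 2-carboxyethyl on the amine nitrogen is a 1.1-fold higher number from compound 3 to compound 4 (0.06 log units; within the scatter), so on this core the two groups cannot be told apart, even though the second is smaller and lacks a defined stereocentre. The earlier step at this nitrogen, a 2.8-fold higher number from compound 1 to compound 2 (0.45 log units; beyond the scatter), lay beyond the scatter, which shows that a change in the acid-bearing chain does not always move the number, at least across these two cores and pairs of groups. Nothing available here offers an explanation for either result.

Open, as far as these compounds go, is whether carboxymethyl, the group of compound 2, would shift the number on the core of compound 3, as it did on the core of compound 1. Also open, from the compounds shown here alone, is what an amide or a longer chain ending in a carboxylic acid would do on this nitrogen.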